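Chain-extended pyrazine amides: cytotoxicity in Vero cells

The source may report more compounds than this note shows. Statements on the series, on what has been measured and on what is new or still open speak of the compounds shown alone.

Compound 1 `CCCCCCNc1cnc(C(=O)NCc2ccccc2)cn1`: >= 100000 nM
Compound 2 `CCCCCCNc1cncc(C(=O)NCc2ccccc2)n1`: 100000 nM
Compound 3 `CCCCNc1nccnc1C(=O)NCc1ccccc1`: > 100000 nM

Three amides sharing the same core have been examined in an ADME assay on Vero cells (Chlorocebus sabaeus) for cytotoxicity, read by microscopy, with a stated time of 6 days; a higher number here means that more compound is tolerated, a lower number that less compound is tolerated. For compound 1 the value given in this assay, >= 100000 nM, is a limit of the assay, described by the limit of >= 100000 nM in this assay, at which 1 of the 3 values shown sits. Compound 2 gives 100000 nM in this assay. For compound 3 the value in this assay, > 100000 nM, is likewise a limit rather than a number, as shown by the limit of > 100000 nM in this assay, at which 1 of the 3 values shown sits. Compound 3 therefore stands at the top of what this assay can report, and none of the three compounds shows a difference from the others that reaches beyond the scatter.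

Compound 4 `CCCCCNc1nccnc1C(=O)NCc1ccccc1` is the next compound to be measured in this assay. It differs from compound 3 in one place: methyl in place of hydrogen on a saturated chain carbon, four bonds along the chain from a nitrogen on an aromatic ring. For the measured compounds named here, no step between measured compounds is available for this change. Given that compound 3 sits at the assay limit with > 100000 nM, the step of a number no higher from compound 3 to compound 4 (the limit leaves the size open) is expected to stay within the scatter. Compound 4 is estimated at 100000 nM, within a range from 50000 nM to 100000 nM.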

Compound 4, minimum cytotoxic concentration: > 100000 nM
Compound 4: a limit, no number (the forecaster's own chance of this, stated with the estimate: 70%); the middle value lies on the limit itself.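

Compound 3 and compound 4 both stand at limits of this assay, and the step between them cannot be read. The compounds shown leave open whether methyl in place of hydrogen at this place on the chain changes the tolerated concentration at all.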